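The source may report more compounds than this note shows. Statements on the series, on what has been measured and on what is new or still open speak of the compounds shown alone.

Compound 1 `CCCn1cnc2c(N)nc(NCCCc3ccccc3)nc21` and compound 3 `CCCn1cnc2c(NCc3ccccc3)ncnc21` share the same scaffold but differ in the groups attached to it; the difference between the two cores is not broken down here. Among the measured compounds shown here, in an assay on CHO cells for displacement of a labelled ligand from transmembrane domain-containing protein TMIGD3 (Homo sapiens) (a higher number here means a weaker inhibitor, a lower number a stronger inhibitor), compound 1 gives 12600 nM, while compound 3 gives 29100 nM, the highest number of the three measured so far and beyond the scatter relative to compound 1.

Compound 2 `CCCn1c(Br)nc2c(N)nc(NCCCc3ccccc3)nc21` carries bromo in place of hydrogen on an aromatic carbon. In this assay compound 2 gives 1950 nM, which is a 6.5-fold lower number from compound 1 to compound 2 (0.81 log units; beyond the scatter).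

Compound 4 `CCCn1c(Br)nc2c(NCc3ccccc3)ncnc21` carries bromo in place of hydrogen on an aromatic carbon. Both place descriptions read the same word for word, so compound 3 to compound 4 is the same change as compound 1 to compound 2, applied to the other core. For the measured compounds named here, only one measured example of this change exists, so the expectation rests on that single pair. For compound 4 the step is expected to be a 6.5-fold lower number from compound 3 to compound 4 (0.81 log units; beyond the scatter), because of the size of a 6.5-fold lower number from compound 1 to compound 2 (0.81 log units; beyond the scatter). Compound 4 is therefore estimated at 4500 nM in this assay, with a range from 1800 nM to 12000 nM.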

Compound 4, inhibition constant: 11100 nM
Beside the measured number, compound 4's estimate is 2.5-fold (0.39 log units) below it; the measured number falls inside the stated range.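

In this assay, bromo in place of hydrogen on the aromatic carbon between two ring nitrogen atoms again gives a lower number, with a 2.6-fold lower number from compound 3 to compound 4 (0.42 log units; beyond the scatter), so the direction of the step holds on the second core. The two steps can be read as one effect of the same size on both cores: the same change on two cores in this assay, a 6.5-fold lower number (0.81 log units; beyond the scatter) from compound 1 to compound 2 and a 2.6-fold lower number (0.42 log units; beyond the scatter) from compound 3 to compound 4, 2.5-fold (0.39 log units) apart, within the scatter of two such steps. Among the compounds shown here, with only two pairs, this supports carrying the change between these two cores, but it says nothing about any further core and does not show why the number falls.

Open, on these data alone, is whether chloro, iodo, methyl or an amine at the same carbon would give a step of similar size. Also open, as far as these compounds go, is whether the bromo step persists when the propyl group gives way to a longer chain or to a chain ending in a carboxylic acid.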